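The compounds below may be only part of what the source reports. "The series", "measured", "known", "first", "only" and "open" are said of these compounds alone.

Of the compounds shown here, three of this set have been measured in a functional assay on TK-10 cells (Homo sapiens) for inhibition, read by sulforhodamine B assay, with a stated time of 48 h; on this read-out higher numbers stand for weaker inhibition of growth and lower numbers for stronger inhibition of growth. Compound 1, with the structure `N=C(N)c1ccc(-c2ccc(-c3ccc(Cl)cc3)o2)o1`, gives 2070 nM. Compound 2, with the structure `N=C(N)c1ccc(-c2ccc(-c3ccc(Cl)cc3)s2)s1`, gives 1960 nM. Compound 3, with the structure `N=C(N)c1ccc(-c2ccc(-c3cncc4ccccc34)s2)s1`, gives 1840 nM. Compound 2 thus holds the second highest of the three numbers, but its nearest neighbour compound 1 and its furthest neighbour compound 3 both lie within the usual scatter of it, so the three measured compounds cannot be told apart on this read-out.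

Compound 4, with the structure `N=C(N)c1ccc(-c2ccc(-c3ccc(F)cc3)s2)s1`, has not yet been measured. It differs from compound 2 in a single place: fluoro in place of chloro on an aromatic carbon. Among the measured compounds shown here, no pair of measured compounds in this set differs in only one place, so there is no measured step on which to rest a prediction, and the three values that exist all sit together. Against this background the change from compound 2 to compound 4 is expected to give no step beyond the scatter in this assay, and the estimated 1.1-fold higher number from compound 2 to compound 4 (0.05 log units; within the scatter) reflects that. Compound 4 is therefore expected to give about 2200 nM, with a likely range from 1100 nM to 4400 nM.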

Compound 4, concentration for 50% growth inhibition: 1720 nM
Estimate against measurement, compound 4: 1.3-fold (0.11 log units) above, within the range that was stated.
By their numbers in this assay, from the lowest: compounds 4, 3, 2 and 1 (each within the scatter of the next).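

Among the compounds shown here, this is the first step in the set that changes a single place, and at this aromatic carbon, para to a large group, fluoro in place of chloro gives a 1.1-fold lower number from compound 2 to compound 4 (0.06 log units; within the scatter) in this assay and so leaves compound 4 indistinguishable from its parent. The earlier compounds shown here showed only that structures differing in more than one place gave values close together, whereas this pair shows that exchanging one of these halogens for the other, each a single heavy atom with no hydrogen-bond donors or acceptors, does not shift the read-out beyond the scatter. Nothing among the information given here accounts for the two halogens reading alike.

The compounds shown leave open whether a different kind of group at this position, such as an amine, a carboxylic acid or a longer chain, would move the number beyond the scatter. They also leave open whether fluoro in place of chloro would behave the same way on the core of compound 1, and whether any single change to this series can separate its members in this read-out.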